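Ethyl to Methyl on the Ring Nitrogen: Stability Unchanged?

The compounds below may be only part of what the source reports. "The series", "measured", "known", "first", "only" and "open" are said of these compounds alone.

Measured in an ADME assay on microsomes from liver (Mus musculus) for metabolic stability, read by LC-MS, with a stated time of 10 min; on this read-out higher numbers stand for a more stable compound and lower numbers for a less stable compound:
Compound 1 `c1cnc2c(c1)CCC[C@@H]2N(CC1CC1)C[C@H]1Cc2c(cccc2N2CCNCC2)CN1`: 88.3%
Compound 2 `c1cnc2c(c1)CCC[C@@H]2N(CC1CCCCC1)C[C@H]1Cc2c(cccc2N2CCNCC2)CN1`: 85.6%
Compound 3 `CCN1CCN(c2cccc3c2C[C@H](CN(C)[C@H]2CCCc4cccnc42)NC3)CC1`: 18.8%

Compound 3 stands lowest of the three, with compound 2 and compound 1 both well beyond the scatter above it. Compound 4 `CN1CCN(c2cccc3c2C[C@H](CN(C)[C@H]2CCCc4cccnc42)NC3)CC1` differs from compound 3 in one place: hydrogen in place of methyl on a saturated chain carbon bound to an amine nitrogen in a ring. Among the measured compounds shown here, the only measured step, a number 2.7 percentage points lower from compound 1 to compound 2 (within the scatter), concerns a different part of the shared core and lay within the scatter, so it gives no direct guide to this cut. With nothing in the data that speaks for a move in either direction, no change beyond the scatter is expected. Compound 4 is therefore estimated at 22%, with a range from 8% to 45%, an expected step of a number 3.2 percentage points higher from compound 3 to compound 4 (within the scatter).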

Compound 4, percent of the compound remaining: 17%
Compound 4: middle estimate off by 5 percentage points, on the high side, within the range that was stated.
By their numbers in this assay, from the lowest: compounds 4 and 3 (each within the scatter of the next); then compounds 2 and 1 (each within the scatter of the next).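

In this assay the change from 4-ethylpiperazin-1-yl to 4-methylpiperazin-1-yl gives a number 1.8 percentage points lower from compound 3 to compound 4 (within the scatter) and so does not shift the read-out beyond the usual scatter. At this position, then, shortening the chain by one carbon leaves the stability of this pair effectively the same. No measurement offered here explains this result. On these data alone, it remains open whether a longer chain such as propyl, or an acetyl group, in this place would move the number beyond the scatter.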